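The source may hold more compounds than are shown below. What is called first, only, known or untested is meant among the compounds shown, and "the series" means these compounds.

Of the compounds shown here, three have been tested so far in a functional assay on EL4 cells (Mus musculus) for inhibition, tested at 100 uM; a higher number here means more inhibition at the concentration tested (going by the name of the read-out), a lower number less inhibition. Going by the values given here, compound 1, with structure `OC[C@H]1O[C@@H](n2cnc3c(Cl)nccc32)C[C@@H]1O`, is reported only as a limit of the assay: in this assay compound 1 gives < 5%. the limit of < 5% in this assay, at which 1 of the 3 values shown sits, is the only such reading among the three. Compound 2, with structure `CN(C)c1[nH]ccc2ncnc1-2`, gives 25% in this assay. Compound 3, with structure `C[C@H]1OC(n2cnc3c(N)nccc32)[C@H](O)[C@@H]1O`, gives 32% in this assay. Of the two numeric readings, compound 2 stands the lower, yet the gap to compound 3 lies within the usual scatter, so the two cannot be told apart on these numbers.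

Compound 4, with structure `CSc1[nH]ccc2ncnc1-2`, has not yet been measured in this assay. It differs from compound 2 in one place: methylsulfanyl in place of dimethylamino on an aromatic carbon. Among the compounds with values here, no measured pair in this set shows what such a swap does, so the expected step is small. The step of a number 5 percentage points lower from compound 2 to compound 4 (within the scatter) is expected to stay within the scatter, with no clear direction. Compound 4 is therefore estimated at 20% in this assay, with a range from 6% to 38%.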

Compound 4, a percentage reported as inhibition, at one concentration (the size of the read-out at that concentration, not a potency): < 5%
Compound 4 gave a limit, no number; the forecaster's own chance of this, stated with the estimate: 15%; middle value at least 15 percentage points from the limit.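

In this assay, going by these compounds alone, the swap of dimethylamino for methylsulfanyl on this aromatic carbon, next to the ring nitrogen, is the first single change that can be read, and the result is a number at least 20 percentage points lower from compound 2 to compound 4 (beyond the scatter). This position is therefore not indifferent to what it carries, even though neither group has a ring or a net charge and the two match in hydrogen-bond donors and acceptors. Compound 4 is reported only as a limit, not a number, so the full size of the step stays unknown: the limit of < 5% in this assay, at which 2 of the 4 values shown sit.

With only these two groups shown at this position, it remains open whether the difference follows from the nitrogen, the sulfur or the number of methyl groups. A primary amine, a methoxy group or a longer chain on the same carbon could help separate these possibilities in this assay.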